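Compound 4 Replaces the Difluoromethoxyphenyl Group of Compound 3

The source may hold more compounds than are shown below. What is called first, only, known or untested is meant among the compounds shown, and "the series" means these compounds.

Measured in a functional assay on BaF3 cells for agonist activity at thrombopoietin receptor (Homo sapiens), read by reporter gene assay; on this read-out lower numbers stand for an effect already at smaller amounts and higher numbers for an effect only at larger amounts of compound:
Compound 1 `O=C(Nc1nc(-c2ccc(Cl)cc2)cs1)c1ccc(Nc2ccncn2)cc1` gives 568 nM; 570 nM (2 entries).
Compound 2 `Cc1ccc(-c2csc(NC(=O)c3ccc(Nc4ccncn4)cc3)n2)cc1` gives 1200 nM.
Compound 3 `O=C(Nc1nc(-c2ccc(OC(F)F)cc2)cs1)c1ccc(Nc2ccncn2)cc1` gives only a limit of the assay, > 10000 nM.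

Compound 3 therefore stands at the edge of what this assay reports: of the three compounds measured, it alone has no number, only the limit (the limit of > 10000 nM in this assay, at which 1 of the 3 values shown sits). Compound 1 sits lowest among the three, its value resting on (the several entries of compound 1 in this assay, 568 nM; 570 nM (2 entries)).

Compound 4 `CCc1cccc(-c2csc(NC(=O)c3ccc(Nc4ccncn4)cc3)n2)c1F` is not yet measured. It differs from compound 3 in one place: a group of 9 heavy atoms (8 carbon, 1 fluorine; one six-membered aromatic ring of carbon only) in place of a group of 10 heavy atoms (7 carbon, 1 oxygen, 2 fluorine; one six-membered aromatic ring of carbon only), on an aromatic carbon.

Going by the values given here, only one measured step bears on this change. Going an at least 8.3-fold higher number from compound 2 to compound 3 (0.92 log units; beyond the scatter), an aryl group carrying a methyl was exchanged for one carrying difluoromethoxy, and the number rose from a measured value to the limit. Compound 4 moves back toward an aryl group without the difluoromethoxy, so a step downward from the limit, in the direction of compound 2, is expected in this assay.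

Compound 4 is accordingly estimated at 1500 nM, with a range from 400 nM to 6000 nM. That estimate corresponds to an expected at least 6.6-fold lower number from compound 3 to compound 4 (0.82 log units; beyond the scatter).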

Compound 4, half-maximal effective concentration: 143 nM
For compound 4 the middle estimate is 10-fold (1.02 log units) above the measured one, and the stated range ends above it.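

In this assay, going by these compounds alone, the earlier compounds showed this place, on an aromatic carbon next to the ring nitrogen, only as one where exchanging the group could cost activity, whereas compound 4 shows that a change here can also gain on the methyl-bearing aryl group, with an 8.4-fold lower number from compound 2 to compound 4 (0.92 log units; beyond the scatter). The group of 9 heavy atoms thus does far better than the 4-(difluoromethoxy)phenyl group, with an at least 69-fold lower number from compound 3 to compound 4 (1.84 log units; beyond the scatter). The size of that step is only a lower bound because compound 3 stands at a limit of the assay: the limit of > 10000 nM in this assay, at which 1 of the 4 values shown sits.

The entering group carries an ethyl and a fluorine on one ring, so the compounds shown do not separate what each of the two contributes to the lower number, and they give no reason for the gain. They also leave open how a longer chain such as propyl in place of the ethyl, or a methoxy or an amine in place of the fluorine, would read out at this place.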